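A few compounds are considered here, and "the series" means these few. Any claim that something is new, unique, unknown or untested is made for them only; others in the source may bear on it.

Measured so far in an ADME assay on L02 cells (Homo sapiens) for antiproliferative activity, read by MTT assay, with a stated time of 48 h; on this read-out lower numbers stand for stronger inhibition and higher numbers for weaker inhibition:
- compound 1 `CCn1c(C(=O)NCCN(C)C)ccc1C(CC)(CC)c1ccc(OCCC(O)(CC)CC)c(C)c1`: 990 nM
- compound 2 `CCn1c(C(=O)NCCN)ccc1C(CC)(CC)c1ccc(OCCC(O)(CC)CC)c(C)c1`: 2940 nM
- compound 3 `CCC(C)C(NC(=O)c1ccc(C(CC)(CC)c2ccc(OCCC(O)(CC)CC)c(C)c2)n1CC)C(=O)O`: 9990 nM

Compound 3 has the highest number of the three and is the weakest inhibitor in this assay. Next in line is compound 4 `CCn1c(C(=O)NC(C)CO)ccc1C(CC)(CC)c1ccc(OCCC(O)(CC)CC)c(C)c1`, which keeps the shared core and differs from compound 3 only on the amide-type nitrogen: 1-(hydroxymethyl)ethyl in place of 1-carboxy-2-methylbutyl on an amide-type nitrogen.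

Two measured steps end in the same 1-carboxy-2-methylbutyl group at this place: a 10-fold higher number from compound 1 to compound 3 (1.00 log units; beyond the scatter) and a 3.4-fold higher number from compound 2 to compound 3 (0.53 log units; beyond the scatter). Both are modest, and both rise towards compound 3. Read in reverse, they suggest that replacing this group could lower the number. The size of that drop depends on the replacement, as a 3.0-fold higher number from compound 1 to compound 2 (0.47 log units; beyond the scatter) shows. Within the data shown here, no measured compound carries 1-(hydroxymethyl)ethyl, so neither step transfers directly. The smaller of the two, a 3.4-fold higher number from compound 2 to compound 3 (0.53 log units; beyond the scatter), serves as a rough guide to the size.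

The expected change is modest and towards stronger inhibition: a 2.5-fold lower number from compound 3 to compound 4 (0.40 log units; beyond the scatter). For compound 4 the estimated value is 4000 nM, with an expected range from 1500 nM to 10000 nM.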

Compound 4, half-maximal inhibitory concentration: 4840 nM
Beside the measured number, compound 4's estimate is 1.2-fold (0.08 log units) below it; the measured number falls inside the stated range.
By their numbers in this assay, from the lowest: compound 1; then compounds 2 and 4 (each within the scatter of the next); then compound 3.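

In this assay, the new group gives a 2.1-fold lower number from compound 3 to compound 4 (0.31 log units; beyond the scatter), so replacing 1-carboxy-2-methylbutyl with the smaller 1-(hydroxymethyl)ethyl on the amide-type nitrogen lowers the number, although the hydrogen-bond donor and acceptor counts of the two groups are the same. A group with neither a carboxy nor an amino function also sits level with the primary amine, with a 1.6-fold higher number from compound 2 to compound 4 (0.22 log units; within the scatter), so on these values the 2-aminoethyl and 1-(hydroxymethyl)ethyl groups cannot be told apart, while the 2-(dimethylamino)ethyl group stays ahead, with a 4.9-fold higher number from compound 1 to compound 4 (0.69 log units; beyond the scatter). No measurement available here accounts for any of these differences.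

The step from compound 3 to compound 4 changes the size of the group and replaces the carboxylic acid with a hydroxymethyl in one move, so the two changes cannot be separated; a 1-carboxyethyl group on the same nitrogen would bear on this. From the compounds shown here alone, whether the advantage of compound 1 belongs to the tertiary amine as such remains open, and a 2-(diethylamino)ethyl group or a longer 3-(dimethylamino)propyl chain would test that.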